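Swapping an Open Amine Chain for a Cyclic Alcohol

The compounds below may be only part of what the source reports. "The series", "measured", "known", "first", "only" and "open" are said of these compounds alone.

Three compounds share one core. Compound 1 `CC(C)(C)OC(=O)NCCCCNC(=O)CN1CN(c2ccccc2)C2(CCN(C(=O)c3ccc(C(C)(C)C)cc3)CC2)C1=O` was tested in an assay on HEK293 cells for displacement of a labelled ligand from NPC1-like intracellular cholesterol transporter 1 (Homo sapiens) (a lower number here means a stronger inhibitor, a higher number a weaker inhibitor), but its entry reads "not determined" (no result reported), so no result was reported for it. Compound 2 `CCC1CCCN(C(=O)CN2CN(c3ccccc3)C3(CCN(C(=O)c4ccc(C5CCCCC5)cc4)CC3)C2=O)C1` gives 2600 nM in this assay. Compound 3 `CC(C)(C)c1ccc(C(=O)N2CCC3(CC2)C(=O)N(CC(=O)NCCCN)CN3c2ccccc2)cc1` gives 4200 nM in this assay, the higher of the two reported numbers; the gap to compound 2 lies within the scatter of repeated runs, so the two cannot be told apart on these data. Compound 4 `CC(C)(C)c1ccc(C(=O)N2CCC3(CC2)C(=O)N(CC(=O)N2CCCCC2CO)CN3c2ccccc2)cc1` has not yet been measured. It differs from compound 3 in one place: 2-(hydroxymethyl)piperidin-1-yl in place of (3-aminopropyl)amino on a carbonyl carbon. Among the measured compounds shown here, no pair of measured compounds differs in only a single place, so there is no measured step of this kind to lean on, and the few numbers at hand give no pattern. A step of a 1.4-fold lower number from compound 3 to compound 4 (0.15 log units; within the scatter) is expected, a small one that need not exceed the scatter, in the direction of a slightly lower number. Compound 4 is estimated at 3000 nM in this assay, with a likely range from 800 nM to 12000 nM.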

Compound 4, half-maximal inhibitory concentration: 11800 nM
Estimate against measurement, compound 4: 3.9-fold (0.59 log units) below, and the stated range covers the measured number.
By their numbers in this assay, from the lowest: compounds 2 and 3 (each within the scatter of the next); then compound 4.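

In this assay, putting 2-(hydroxymethyl)piperidin-1-yl in place of (3-aminopropyl)amino on the carbonyl carbon gives a 2.8-fold higher number from compound 3 to compound 4 (0.45 log units; beyond the scatter). Among the compounds shown here, this is the first measured change at a single place in this set, and it shows that the group on this carbonyl can shift the inhibitor's strength beyond the scatter, though only modestly, and here towards a weaker inhibitor. No measurement at hand bears on why the number rose.

Going by these compounds, this one step swaps an open chain for a ring and a terminal amine for an alcohol at the same time, so the contribution of each swap stays open. A plain piperidin-1-yl, or a 2-(aminomethyl)piperidin-1-yl with an amine in place of the alcohol, would help to pull these two swaps apart.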